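Swapping the pyridyl amide substituent on a tricyclic hydroxy-lactam

This account rests on a few compounds, and the source may have more. Where it says the series, first, only, none or still open, it means among the compounds named here.

Measured compounds:
compound 1 `O=C(Nc1ccccc1)c1c(O)c2cccnc2n(-c2ccccc2)c1=O` gives 4.6%
compound 2 `Cc1cnccc1NC(=O)c1c(O)c2cccnc2n(-c2ccccc2)c1=O` gives 26.9%

Both numbers come from a functional assay on the whole organism for inhibition, with Rattus norvegicus as the target, read by paw edema, at a dose of 100 mg/kg by the oral route; a lower number here means less inhibition, a higher number more inhibition at the dose given (going by the name of the read-out). Going by the values given here, compound 2 stands highest of the two, and the one step measured, a number 22.3 percentage points higher from compound 1 to compound 2 (beyond the scatter), was modest but beyond the scatter. Compound 3 `O=C(Nc1ccc(Cl)nc1)c1c(O)c2cccnc2n(-c2ccccc2)c1=O` differs from compound 2 by 6-chloropyridin-3-yl in place of 3-methylpyridin-4-yl on an amide-type nitrogen. Among the compounds with values here, no measured step covers this exchange of one pyridyl group for another; the single known step only shows that replacing phenyl with a pyridyl can raise inhibition. With no direct guide, compound 3 is expected to land at 15%, in the range 0% to 35%, which means an estimated step of a number 11.9 percentage points lower from compound 2 to compound 3 (beyond the scatter).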

Compound 3, a percentage reported as inhibition, in the whole organism at one dose (the size of the read-out at that dose, not a potency): 9.2%
Compound 3: middle estimate off by 5.8 percentage points, on the high side, and the stated range covers the measured number.
By their numbers in this assay, from the lowest: compounds 1 and 3 (each within the scatter of the next); then compound 2.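

A pyridyl group on the amide-type nitrogen does not bring higher inhibition by itself: in this assay, the exchange of one pyridyl for another gives a real loss (a number 17.7 percentage points lower from compound 2 to compound 3 (beyond the scatter)). The 6-chloropyridin-3-yl group also shows no separation from plain phenyl (a number 4.6 percentage points higher from compound 1 to compound 3 (within the scatter)), so the gain belongs to 3-methylpyridin-4-yl among these compounds. Nothing available here explains this.

Still open, on these data alone, is whether the methyl, the chlorine or the place of the ring nitrogen decides the outcome. As far as these compounds go, how an amine or a carboxylic acid on this ring would read also remains unknown.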